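This account rests on a few compounds, and the source may have more. Where it says the series, first, only, none or still open, it means among the compounds named here.

Compounds measured so far in a functional assay (trachea) with Rattus norvegicus as the target; on this read-out higher numbers stand for higher potency (the scale is a negative logarithm) and lower numbers for lower potency:

Compound 1, `CC1(C)C=C(n2ccccc2=O)c2cc(C(=O)c3ccco3)ccc2O1`, gives 5.92.
Compound 2, `CC1(C)C=C(n2ccccc2=O)c2cc(C(=O)c3ccc([N+](=O)[O-])cc3)ccc2O1`, gives 6.09.

Of these two numbers, compound 2 holds the higher one, though its gap to compound 1 is within the scatter. Compound 3, `CC1(C)C=C(n2ccccc2=O)c2cc(C=O)ccc2O1`, has not yet been measured. The change from compound 2 to compound 3 is hydrogen in place of 4-nitrophenyl on a carbonyl carbon. Among the compounds with values here, only one measured step bears on this position: a number 0.17 log units higher from compound 1 to compound 2 (within the scatter), a swap of one ring for another on the carbonyl carbon that barely moved the read-out. Within the data shown here, removing the ring altogether is a larger change than that swap, and no measured pair shows what such a truncation does here. A modest loss in this assay is therefore expected, estimated as a number 0.59 log units lower from compound 2 to compound 3 (beyond the scatter). Compound 3 is expected to give about 5.5, with a likely range from 4.8 to 6.2.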

Compound 3, logarithm of the reciprocal of the active concentration, log(1/C): 6.14
Beside the measured number, compound 3's estimate is 0.64 log units below it; the measured number falls inside the stated range.
By their numbers in this assay, from the lowest: compounds 1, 2 and 3 (each within the scatter of the next).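

In this assay the ring on the carbonyl carbon turns out to be dispensable: hydrogen in place of 4-nitrophenyl gives a number 0.05 log units higher from compound 2 to compound 3 (within the scatter) and hydrogen in place of furan-2-yl gives a number 0.22 log units higher from compound 1 to compound 3 (within the scatter) on this read-out. The earlier pair only swapped one ring for another, whereas these steps remove the ring altogether, so among these three compounds the read-out does not separate a carbonyl carrying a ring from one carrying only hydrogen. No supporting data are available to explain this result.

Going by these compounds, it remains open whether the carbonyl itself matters, as all three compounds keep it. Also open, on these data alone, is how this assay responds when that carbon carries a carboxylic acid, an amine forming an amide, or a simple methyl.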